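The compounds below may be only part of what the source reports. "The series", "measured", "known", "first", "only" and "open" are said of these compounds alone.

Measured so far:
Compound 1, `O=S(=O)(c1ccc2cccnc2c1)n1cc(C2=CCNCC2)c2cc(Cl)ccc21`: 7320 nM
Compound 2, `COc1ccc2c(c1)c(C1=CCNCC1)cn2S(=O)(=O)c1cccc2ncccc12`: 2350 nM

Of the compounds shown here, two have been tested in an assay on HEK293 cells for displacement of a labelled ligand from 5-hydroxytryptamine receptor 7 (Homo sapiens), read by scintillation counting; on this read-out higher numbers stand for weaker inhibition and lower numbers for stronger inhibition. Compound 1 gives 7320 nM, and compound 2 gives 2350 nM. Compound 2 thus has the lower of the two numbers, and its nearest neighbour, compound 1, sits at a higher number by a margin that is beyond the usual scatter of this assay.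

The next compound, compound 3, `COc1ccc2c(c1)c(C1=CCNCC1)cn2S(=O)(=O)c1ccc2cccnc2c1`, keeps every atom of compound 2 but joins them differently: quinolin-7-yl in place of quinolin-5-yl on a sulfonyl sulfur. Compound 1 differs from compound 3 in more than one place, so its value cannot serve as a guide to this particular change on its own. Among the measured compounds shown here, with no measured pair that isolates the move of the attachment point on the quinoline, the expectation rests on the general observation that such rearrangements often move this read-out only modestly. Compound 3 is therefore expected to show a small step upward from compound 2 in this assay, a 1.5-fold higher number from compound 2 to compound 3 (0.17 log units; within the scatter), of a size near the edge of the scatter. The estimate for compound 3 is 3500 nM, with a likely range from 1200 nM to 10000 nM.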

Compound 3, inhibition constant: 6250 nM
Estimate against measurement, compound 3: 1.8-fold (0.25 log units) below, and the stated range covers the measured number.
By their numbers in this assay, from the lowest: compound 2; then compounds 3 and 1 (each within the scatter of the next).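

In this assay the way the quinoline is joined to the sulfonyl sulfur matters: quinolin-7-yl in place of quinolin-5-yl gives a 2.7-fold higher number from compound 2 to compound 3 (0.42 log units; beyond the scatter) and lies beyond the scatter, although the two compounds contain the same atoms. With quinolin-7-yl kept in both compounds, methoxy in place of chloro on an aromatic carbon gives a 1.2-fold lower number from compound 1 to compound 3 (0.07 log units; within the scatter) and stays within the scatter, so this pair shows no real difference between the two groups. The compounds therefore separate on the quinolin-yl change but not on the methoxy and chloro change, and no available measurement explains that result.

Among the compounds shown here, with only one pair for each change, it remains open whether the quinolin-5-yl and quinolin-7-yl difference would carry over when chloro replaces methoxy on the aromatic carbon. Also open, going by these compounds, is how a simple phenyl or a naphthalen-1-yl, which has carbon in place of the quinoline nitrogen, would compare on the sulfonyl sulfur, and whether fluoro or methyl on the aromatic carbon would behave like chloro and methoxy.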